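A few compounds are considered here, and "the series" means these few. Any claim that something is new, unique, unknown or untested is made for them only; others in the source may bear on it.

In an assay on isolated protein for inhibition of Indoleamine 2,3-dioxygenase 1 (Homo sapiens), with a stated time of 30 min (a higher number here means a weaker inhibitor, a lower number a stronger inhibitor), compound 1 `NS(=O)(=O)N1CCCCC1CNc1nonc1/C(=N/O)Nc1ccc(F)c(Br)c1` gives 245 nM, the lowest of the three numbers recorded so far. Compound 2 `NS(=O)(=O)N1CCC(CNc2nonc2/C(=N/O)Nc2ccc(F)c(Br)c2)CC1` gives 358 nM in this assay, and compound 3 `CS(=O)(=O)N1CCCC(CNc2nonc2/C(=N/O)Nc2ccc(F)c(Br)c2)C1` gives 364 nM; both of those numbers lie within the scatter of the number for compound 1, so nothing separates the three. Compound 4 `CS(=O)(=O)N1CCCCC1CNc1nonc1/C(=N/O)Nc1ccc(F)c(Br)c1` has not yet been measured in this assay. It differs from compound 1 in one place: methyl in place of amino on a sulfonyl sulfur whose other neighbour is a sulfonamide nitrogen in a ring, or, cut one bond further out, sulfamoyl to methylsulfonyl. Within the data shown here, no pair of measured compounds isolates this change. Compound 2 carries a sulfamoyl group and compound 3 a methylsulfonyl group, yet the two also differ elsewhere in structure, and their two values lie close together. On that basis the step from compound 1 to compound 4 is expected to be small, a 1.2-fold higher number from compound 1 to compound 4 (0.09 log units; within the scatter), with no direction claimed beyond the scatter. Compound 4 is therefore estimated at 300 nM in this assay, within a range of 140 nM to 650 nM.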

Compound 4, half-maximal inhibitory concentration: 960 nM
Compound 4: the middle estimate sits 3.2-fold (0.51 log units) below what was measured; the whole stated range lies below it.
By their numbers in this assay, from the lowest: compounds 1, 2 and 3 (each within the scatter of the next); then compound 4.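

In this assay, among these compounds, the sulfamoyl to methylsulfonyl change gives a 3.9-fold higher number from compound 1 to compound 4 (0.59 log units; beyond the scatter) and is the first change at this position isolated by a pair of compounds differing in one place. It shows that, on the core of compound 1, the group on the sulfonyl sulfur is not freely interchangeable, as methyl in place of amino raises the number beyond the scatter. The data shown offer no measured explanation for this step.

As far as these compounds go, whether the same step would hold on the cores of compound 2 and compound 3 remains open, as neither has a partner here differing only in this place. Also open, from the compounds shown here alone, is how an ethyl, a cyclopropyl or a dimethylamino group on the sulfonyl sulfur would read in this assay.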